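Losing the Dimethyl Handle on the Sulfur Side Chain

A few compounds are considered here, and "the series" means these few. Any claim that something is new, unique, unknown or untested is made for them only; others in the source may bear on it.

Of the compounds shown here, three have so far been tested in an assay on isolated protein for inhibition of Retinaldehyde dehydrogenase 3 (Homo sapiens); on this read-out higher numbers stand for weaker inhibition and lower numbers for stronger inhibition. Compound 1 `Cn1ncc2c(=O)n(-c3ccccc3)c(SC(C)(C)c3ccccc3)nc21` gives 1390 nM, the highest of the three numbers. Compound 2 `C#Cc1ccc(-n2c(SC(C)c3ccccc3)nc3c(cnn3C)c2=O)cc1` gives 520 nM, and compound 3 `CC(Sc1nc2nn(CC3COC3)cc2c(=O)n1-c1ccccc1)c1ccccc1` gives 60 nM; both gaps to compound 1 lie beyond the usual scatter, so compound 1 is the weakest inhibitor of the set. Compound 4 `CC(Sc1nc2c(cnn2C)c(=O)n1-c1ccccc1)c1cccc(O)c1` has not yet been measured. It differs from compound 1 in one place: a group of 9 heavy atoms (8 carbon, 1 oxygen; one six-membered aromatic ring of carbon only) in place of a group of 9 heavy atoms (9 carbon; one six-membered aromatic ring of carbon only), on a sulfur. The step of a 4.6-fold lower number from compound 1 to compound 4 (0.67 log units; beyond the scatter) is expected to bring a clearly lower number in this assay, because compound 2 gives 520 nM and compound 3 gives 60 nM without the 1-methyl-1-phenylethyl group. Compound 4 is therefore estimated at 300 nM, with a likely range from 100 nM to 1000 nM.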

Compound 4, half-maximal inhibitory concentration: 91 nM
Estimate against measurement, compound 4: 3.3-fold (0.52 log units) above; measured number outside the range, below it.
By their numbers in this assay, from the lowest: compounds 3 and 4 (each within the scatter of the next); then compound 2; then compound 1.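

Among the compounds shown here, this is the first one-place comparison at the sulfur side chain: replacing the 1-methyl-1-phenylethyl group with the oxygen-bearing group gives a 15-fold lower number from compound 1 to compound 4 (1.18 log units; beyond the scatter), a large step. The entering group has 1 hydrogen-bond donor and 1 hydrogen-bond acceptor, while the leaving group has neither, but the swap changes more than that one feature. Nothing shown gives a cause for this step.

Still open, as far as these compounds go, is how much of the step belongs to the added oxygen and how much to the rest of the swap. Whether a methoxy group or an amine could replace that oxygen is also unknown.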